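Trifluoromethyl in place of chloro: working notes

This account rests on a few compounds, and the source may have more. Where it says the series, first, only, none or still open, it means among the compounds named here.

- compound 1 `C=C(c1ccc(OC)cc1)c1cc(OC)c(OC)c(OC)c1-c1ccccc1` gives 31000 nM in this series
- compound 2 `C=C(c1ccc(C)cc1)c1cc(OC)c(OC)c(OC)c1-c1ccccc1` gives 31000 nM in this series
- compound 3 `C=C(c1ccc(Cl)cc1)c1cc(OC)c(OC)c(OC)c1-c1ccccc1` gives 25000 nM in this series

All three values come from a functional assay on SK-N-SH cells (Homo sapiens) for cytotoxicity, read by MTT assay, with a stated time of 48 h (on this read-out higher numbers stand for weaker inhibition and lower numbers for stronger inhibition), and lie within the scatter of one another. Compound 3 at 25000 nM is thus not separated from the other two. Compound 4 `C=C(c1ccc(C(F)(F)F)cc1)c1cc(OC)c(OC)c(OC)c1-c1ccccc1` is not yet measured and differs from compound 3 thus: trifluoromethyl in place of chloro on an aromatic carbon with trifluoromethyl in place of chloro on an aromatic carbon. Three measured exchanges at this place bear on it: no change at the digits printed from compound 1 to compound 2 (within the scatter) and a 1.2-fold lower number from compound 1 to compound 3 (0.09 log units; within the scatter) and a 1.2-fold lower number from compound 2 to compound 3 (0.09 log units; within the scatter) all stay within the scatter. Trifluoromethyl itself has no measured precedent here. No step beyond the scatter is therefore expected in this assay and no direction is favoured. The expected step is a 1.0-fold higher number from compound 3 to compound 4 (0.02 log units; within the scatter) on this reasoning. For compound 4 the estimate is 26000 nM with an expected range from 13000 nM to 50000 nM for this value.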

Compound 4, half-maximal inhibitory concentration: 13000 nM
Compound 4: middle estimate off by 2.0-fold (0.30 log units), on the high side; low and high end bracket the measured number.
By their numbers in this assay, from the lowest: compounds 4, 3, 1 and 2 (each within the scatter of the next, the first and the last beyond it).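

In this assay, within the data shown here, the steps of a 2.4-fold lower number from compound 2 to compound 4 (0.38 log units; beyond the scatter) and a 2.4-fold lower number from compound 1 to compound 4 (0.38 log units; beyond the scatter) are the first at this position to lie beyond the scatter, though both are modest, while a 1.9-fold lower number from compound 3 to compound 4 (0.28 log units; within the scatter) stays within it. The 4-substituent therefore has some measurable influence on this read-out, but trifluoromethyl cannot be separated from chloro. No measurement available here explains these steps. As far as these compounds go, whether an amine or a carboxylic acid at this place would produce a larger step remains open. Also open, from the compounds shown here alone, is whether trifluoromethyl would give similar steps on a different core.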